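This account rests on a few compounds, and the source may have more. Where it says the series, first, only, none or still open, it means among the compounds named here.

Measured compounds:

- compound 1 `Cc1cn(C2CCN(Cc3cccc(Oc4cc(C(F)(F)F)cc(C(F)(F)F)c4)c3)CC2)c(=O)[nH]c1=O` in an ADME assay on MRC5 cells (Homo sapiens) for cytotoxicity, read by fluorescence and resazurin assay, with a stated time of 3 days; on this read-out higher numbers stand for weaker inhibition and lower numbers for stronger inhibition: "not determined" (no result reported)
- compound 2 `Cc1cn(C2CCN(Cc3cccc(Oc4cc(F)cc(F)c4)c3)CC2)c(=O)[nH]c1=O`: > 64000 nM (a limit of the assay, not a number)
- compound 3 `Cc1cn(C2CCN(Cc3cccc(Oc4ccc(O)cc4)n3)CC2)c(=O)[nH]c1=O`: "not determined" (no result reported)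

Of the three, only compound 2 carries any entry in this assay, and that entry is a limit rather than a measured number. Among the compounds with values here, compound 2 stands at the limit described by the limit of > 64000 nM in this assay, at which 1 of the 3 values shown sits, and no other compound in the set gives a value against which to place it, so no step between measured compounds can be read off.

Compound 4 `Cc1cn(C2CCN(Cc3cccc(Oc4ccc(Cl)c(Cl)c4)c3)CC2)c(=O)[nH]c1=O` is the compound still to be tested. It arises from compound 2 by the change (3,4-dichlorophenyl in place of 3,5-difluorophenyl on an oxygen on an aromatic ring), so that the 3,5-difluorophenoxy group of compound 2 gives way to 3,4-dichlorophenoxy in compound 4. Without any measured step in this set, the writer expects the shift a number no higher from compound 2 to compound 4 (the limit leaves the size open) to stay within the usual scatter, in no particular direction. Compound 4 is therefore estimated to give 64000 nM in this assay, with a range from 16000 nM to 200000 nM, and most likely again only a limit is reported.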

Compound 4, half-maximal inhibitory concentration: 6100 nM
The estimate for compound 4 lay 10-fold (1.02 log units) above the measured number; measured number below the stated range.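

In this assay, the group on the oxygen on an aromatic ring proves able to shift the read-out: 3,4-dichlorophenyl in place of 3,5-difluorophenyl gives an at least 10-fold lower number from compound 2 to compound 4 (1.02 log units; beyond the scatter). Compound 4, at 6100 nM, supplies the only actual number among the compounds shown, so this position now has a step beyond the scatter where the earlier entries offered none. Compound 2 provides only a limit, which leaves the step open-ended: the limit of > 64000 nM in this assay, at which 1 of the 4 values shown sits.

The change swaps the halogen and its placement on the ring together, so the compounds shown do not tell which of the two carries the step, nor how a methoxy group or a nitrile on that ring would read. Steps involving compound 1 and compound 3 cannot be read.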